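Fluoro-hydroxyphenyl amide series: notes on compound 4

The source may report more compounds than this note shows. Statements on the series, on what has been measured and on what is new or still open speak of the compounds shown alone.

Measured compounds:
- Compound 1 `O=C(Nc1ccc(Oc2cc(C(F)(F)F)cc(C(F)(F)F)c2)cc1)c1c(F)cccc1Br`: 6000 nM
- Compound 2 `O=C(Nc1ccc(Oc2cc(C(F)(F)F)cc(C(F)(F)F)c2)cc1)c1cc(I)ccc1F`: "not determined" (no result reported)
- Compound 3 `O=C(Nc1ccc(Oc2cc(C(F)(F)F)cc(C(F)(F)F)c2)cc1)c1c(O)cccc1F`: "not determined" (no result reported)

All three share the same core, an amide linking the diaryl ether aniline to a substituted benzoyl group. In an assay on HEK293 cells for inhibition of Toll-like receptor 8 (Homo sapiens), with a stated time of 16 h (a higher number here means a weaker inhibitor, a lower number a stronger inhibitor), compound 1 gives 6000 nM. Among the measured compounds shown here, for compound 2 this assay returned "not determined" (no result reported), and for compound 3 it likewise returned "not determined" (no result reported), so compound 3 has no number to stand on; the only number is that of compound 1.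

Compound 4 `O=C(Nc1ccc(Oc2cc(C(F)(F)F)cc(C(F)(F)F)c2)cc1)c1ccc(O)cc1F` is the next candidate. The change from compound 3 is 2-fluoro-4-hydroxyphenyl in place of 2-fluoro-6-hydroxyphenyl on a carbonyl carbon, a rearrangement with the same atoms joined differently. With no numbered pair to compare, no step size can be read off, and no direction beyond the scatter can be stated for this assay; the change is treated as open. For the measured compounds named here, on the one available number, that of compound 1, compound 4 is expected to give about 6000 nM, with a wide band from 1500 nM to 25000 nM.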

Compound 4, half-maximal inhibitory concentration: > 50000 nM
Compound 4 ended at the assay's limit (the forecaster's own chance of this, stated with the estimate: 30%); middle value at least 8.3-fold (0.92 log units) away from the limit.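

In this assay, compound 4 gives > 50000 nM, which is a limit of the assay and not a number: the limit of > 50000 nM in this assay, at which 1 of the 4 values shown sits.

Among the compounds shown here, with 2-fluoro-4-hydroxyphenyl in place of 2-bromo-6-fluorophenyl on a carbonyl carbon, this assay shows an at least 8.3-fold higher number from compound 1 to compound 4 (0.92 log units; beyond the scatter), the only step that can be read. The group at this place can therefore shift the read-out beyond the scatter, which compound 1, compound 2 and compound 3 alone could not show.

Steps involving compound 2 or compound 3 cannot be read, so this single step does not separate the loss of the bromine from the placing of the hydroxyl group in 2-fluoro-4-hydroxyphenyl. From the compounds shown here alone, whether an amine or a carboxylic acid in place of that hydroxyl group would bring the number back towards that of compound 1, 6000 nM, also stays open.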